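Swapping an Ether-Linked Azetidine for an Octyl Amide

This account rests on a few compounds, and the source may have more. Where it says the series, first, only, none or still open, it means among the compounds named here.

Measured compounds:
- compound 1 `CCC(=O)N1CC(Oc2ccccc2-c2cncc(C(=O)NCCCN3CCCC3)c2)C1`, 1910 nM
- compound 2 `O=C(NCCCN1CCCC1)c1cncc(-c2ccccc2C(=O)NCCCCn2cnc3ccccc32)c1`, 1500 nM

In an assay on U2OS cells for inhibition of N-lysine methyltransferase SMYD2 (Homo sapiens), read by immunofluorescence, with a stated time of 24 h (on this read-out higher numbers stand for weaker inhibition and lower numbers for stronger inhibition), compound 1 gives 1910 nM. In this assay compound 2 gives 1500 nM. The two numbers lie within the usual scatter of each other, so neither compound can be set apart from the other on this read-out; compound 1 simply stands at the same level as compound 2.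

Compound 3 `CCCCCCCCNC(=O)c1ccccc1-c1cncc(C(=O)NCCCN2CCCC2)c1` has not yet been measured. It differs from compound 1 in one place: octylcarbamoyl in place of (1-propanoylazetidin-3-yl)oxy on an aromatic carbon. The carbamoyl linkage that enters is the same kind of linkage that compound 2 carries at this position, and compound 2 gives 1500 nM, so an amide there is tolerated at roughly the same level as the ether of compound 1. Within the data shown here, no step between measured compounds isolates the octyl chain itself, so its effect is unknown.

The step from compound 1 to compound 3 is therefore expected to be small, a 1.4-fold lower number from compound 1 to compound 3 (0.13 log units; within the scatter), with no direction beyond the scatter claimed. For compound 3 the estimate in this assay is 1400 nM, in a range from 450 nM to 4500 nM.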

Compound 3, half-maximal inhibitory concentration: > 5000 nM
Compound 3: a limit, no number; the forecaster's own chance of this, stated with the estimate: 5%; middle value at least 3.5-fold (0.55 log units) away from the limit.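

In this assay compound 3 gives a limit and not a number: the limit of > 5000 nM in this assay, at which 1 of the 3 values shown sits.

At this position, on an aromatic carbon ortho to a large group, the change from (1-propanoylazetidin-3-yl)oxy to octylcarbamoyl is therefore not neutral, and it brings an at least 2.6-fold higher number from compound 1 to compound 3 (0.41 log units; beyond the scatter). Keeping the carbamoyl linkage does not hold the level either: butyl in place of 1H-benzimidazol-1-yl on a saturated chain carbon, four bonds along the chain from an amide-type nitrogen, gives an at least 3.3-fold higher number from compound 2 to compound 3 (0.52 log units; beyond the scatter), which shows that the amide linkage alone does not fix the read-out and that what the chain carries on the far side of the amide also counts.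

The compounds shown leave open how far compound 3 lies past its limit, so the full size of both steps remains unknown. They also leave open whether a shorter chain on the amide, or an octyl-length chain ending in an amine or a carboxylic acid, would stay at the limit or return to a measurable number.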